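Replacing a small selenium group with a longer chain

The source may hold more compounds than are shown below. What is called first, only, known or untested is meant among the compounds shown, and "the series" means these compounds.

Three compounds have been measured in a functional assay on HepG2 cells (Homo sapiens) for inhibition, read by MTT assay, with a stated time of 48 h (on this read-out lower numbers stand for stronger inhibition and higher numbers for weaker inhibition), so far:

- Compound 1 `COc1ccc(N(C)c2nc(C)nc3ccccc23)cc1OCCC[Se]C#N` gives 1040 nM
- Compound 2 `COc1ccc(N(C)c2nc(C)nc3ccccc23)cc1C(=O)OCCC[Se]C#N` gives 340 nM
- Compound 3 `COc1ccc(N(C)c2nc(C)nc3ccccc23)cc1[Se]C` gives 17 nM

Compound 3 has the lowest number of the three, and the other two lie well above it. Going on to compound 4 `COc1ccc(N(C)c2nc(C)nc3ccccc23)cc1C(=O)OCCCC[Se]C#N` means a group of 10 heavy atoms (6 carbon, 1 nitrogen, 2 oxygen, 1 selenium; no ring) in place of a group of 2 heavy atoms (1 carbon, 1 selenium; no ring), on an aromatic carbon as the only structural change. Large drops came with the small group, a 61-fold lower number from compound 1 to compound 3 (1.79 log units; beyond the scatter) and a 20-fold lower number from compound 2 to compound 3 (1.30 log units; beyond the scatter) in size, while the exchange between the two long chains gave only a modest step, a 3.1-fold lower number from compound 1 to compound 2 (0.49 log units; beyond the scatter) in size. Compound 4 has the carbonyl-containing chain of compound 2, only longer, so compound 2 at 340 nM is the closest guide. A large rise in the number in this assay is therefore expected, much like undoing a 20-fold lower number from compound 2 to compound 3 (1.30 log units; beyond the scatter) in reverse. The expected step is an 18-fold higher number from compound 3 to compound 4 (1.25 log units; beyond the scatter) in size. For compound 4 the estimated value is 300 nM with an expected range from 100 nM to 900 nM as its ends.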

Compound 4, half-maximal inhibitory concentration: 975 nM
The estimate for compound 4 lay 3.3-fold (0.51 log units) below the measured number; the measured number lies above the stated range.
By their numbers in this assay, from the lowest: compound 3; then compound 2; then compounds 4 and 1 (each within the scatter of the next).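

In this assay, lengthening the carbonyl-containing chain alone gives a 2.9-fold higher number from compound 2 to compound 4 (0.46 log units; beyond the scatter) and so shows that chain length at this aromatic carbon changes the number by itself, beyond the exchange of one chain type for another. The advantage of compound 2 is not kept on lengthening, since a 1.1-fold lower number from compound 1 to compound 4 (0.03 log units; within the scatter) leaves compound 4 level with the chain lacking the carbonyl, while a 57-fold higher number from compound 3 to compound 4 (1.76 log units; beyond the scatter) confirms that the long chain stands far from the small selenium group at this position. Nothing available explains these steps.

The compounds shown leave open how a still longer chain would read here, and whether the trend with length holds beyond this single pair. They also leave open whether the nitrile end matters, as a chain ending in an amine or a carboxylic acid would show.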